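Methyl on the piperazine of compound 2

The compounds below may be only part of what the source reports. "The series", "measured", "known", "first", "only" and "open" are said of these compounds alone.

In a functional assay on DU-145 cells (Homo sapiens) for antiproliferative activity, read by MTT assay (on this read-out lower numbers stand for stronger inhibition and higher numbers for weaker inhibition), compound 1 `c1ccc(N2CCN(c3nc(-n4ccc5ccccc54)c4ccccc4n3)CC2)cc1` gives 50 ug/mL. Compound 2 `Cn1cc(-c2nc(N3CCNCC3)nc3ccccc23)c2ccccc21` gives 50 ug/mL, level with compound 1 at the digits shown. Going by the values given here, no measured pair differs in one place, so the data offer no direct guide to a single change.

Compound 3 `CN1CCN(c2nc(-c3cn(C)c4ccccc34)c3ccccc3n2)CC1` is compound 2 with piperazin-1-yl turned into 4-methylpiperazin-1-yl, that is, methyl in place of hydrogen on an amine nitrogen in a ring. The expectation rests on compound 2 at 50 ug/mL, the closest measured structure. The expected change in this assay is no change at the digits printed from compound 2 to compound 3 (within the scatter), with no estimated shift in either direction beyond the scatter. For compound 3 the estimated value is 50 ug/mL, with an expected range from 22 ug/mL to 100 ug/mL.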

Compound 3, half-maximal inhibitory concentration: 50 ug/mL
Compound 3: middle estimate and measured number agree at the digits printed, within the range that was stated.
By their numbers in this assay, from the lowest: compounds 1, 2 and 3 (each within the scatter of the next).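

The series now holds its first step that changes a single place: in this assay, methyl in place of hydrogen on an amine nitrogen in a ring gives no change at the digits printed from compound 2 to compound 3 (within the scatter). On this six-membered non-aromatic ring, the hydrogen on that nitrogen is therefore not needed to keep the read-out at this level, and a single methyl there does not move it. This holds for one small group on one compound, with the rest of the structure of compound 2 kept unchanged.

From the compounds shown here alone, whether a larger group on the same nitrogen, such as an acetyl or a longer chain, or a carboxylic acid carried on such a chain, would depart from this level remains open. No measurement at hand bears on the reason for this step.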